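This account rests on a few compounds, and the source may have more. Where it says the series, first, only, none or still open, it means among the compounds named here.

Going by the values given here, in an ADME assay on microsomes from liver (Rattus norvegicus) for metabolic stability, read by LC-MS, with a stated time of 10 min, tested at 0.5 uM (a lower number here means that less of the compound is left, a higher number that more of the compound is left), compound 1 `c1ccc2c(c1)CN[C@@H](CN(CC1CCNCC1)[C@H]1CCCc3cccnc31)C2` gives 65%, while compound 2 `NC(=O)N1CCN(CCCN(C[C@H]2Cc3ccccc3CN2)[C@H]2CCCc3cccnc32)CC1` gives 4%, the lower of the two numbers measured so far. Compound 3 `c1ccc2c(c1)CN[C@@H](CN(CCCN1CCN(C3CC3)CC1)[C@H]1CCCc3cccnc31)C2` has not yet been measured. It differs from compound 2 in one place: cyclopropyl in place of carbamoyl on an amine nitrogen in a ring. In words, this is cyclopropyl in place of carbamoyl on an amine nitrogen in a ring.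

Among the compounds with values here, only one measured step bears on this change, and only indirectly. It is the large drop a number 61 percentage points lower from compound 1 to compound 2 (beyond the scatter). The group that entered on that step carries the carbamoyl that now leaves, but the step replaced a much bigger piece of the molecule. It therefore cannot show what the carbamoyl alone contributes. Within the data shown here, no measured pair isolates this swap, so little guidance exists on its direction. Compound 2 starts at 4%, so a small rise in this assay seems the more likely outcome. The expected change is a number 6 percentage points higher from compound 2 to compound 3 (within the scatter), a step estimated to stay within the usual scatter. For compound 3 the estimate is 10%, with an expected range from 2% to 30%.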

Compound 3, percent of the compound remaining: 2%
The estimate for compound 3 lay 8 percentage points above the measured number; the range from low to high includes it.
By their numbers in this assay, from the lowest: compounds 3 and 2 (each within the scatter of the next); then compound 1.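

Replacing carbamoyl with cyclopropyl on the amine nitrogen in the ring amounts, in this assay, to a number 2 percentage points lower from compound 2 to compound 3 (within the scatter) and so gives no measurable difference between these two groups at this position, although carbamoyl carries a hydrogen-bond donor and acceptor and cyclopropyl carries neither. The large loss seen earlier also does not need the carbamoyl, since the other route to the same kind of group gives a number 63 percentage points lower from compound 1 to compound 3 (beyond the scatter) and the cyclopropyl compound shows it just as clearly. The low numbers therefore go with what compound 2 and compound 3 share in place of the smaller group of compound 1, and nothing measured here explains why the compound disappears so quickly.

Both compounds lie so close to the bottom of the scale that any further loss from a new group on this nitrogen would be hard to see, so only a rise would be informative. As far as these compounds go, whether a methyl or an acetyl on this nitrogen, or a piperidine in place of the piperazine, would bring the number back toward that of compound 1 remains open.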